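Compound 3 to compound 4: adding a dimethylamino group

The compounds below may be only part of what the source reports. "The series", "measured", "known", "first", "only" and "open" are said of these compounds alone.

Values measured in a functional assay on A549 cells (Homo sapiens) for inhibition, read by sulforhodamine B assay; a higher number here means a weaker inhibitor of growth, a lower number a stronger inhibitor of growth
compound 1 `c1ccc(-c2ccc(-c3ccc(-c4nc5ccccc5[nH]4)cc3)cc2)cc1` gives 41200 nM
compound 2 `COc1ccc(-c2ccc(-c3ccc(-c4nc5ccccc5[nH]4)cc3)cc2)cc1OC` gives 7600 nM
compound 3 `Oc1cccc2[nH]c(-c3ccc(-c4ccc(-c5ccccc5)cc4)cc3)nc12` gives 8320 nM

Compound 3 cannot be separated from compound 2 in this assay and both carry lower numbers than compound 1. The change to compound 4 `CN(C)c1ccc(-c2ccc(-c3ccc(-c4nc5c(O)cccc5[nH]4)cc3)cc2)cc1` is dimethylamino in place of hydrogen on an aromatic carbon and amounts to dimethylamino in place of hydrogen on an aromatic carbon, with phenyl becoming 4-(dimethylamino)phenyl. Compound 4 keeps the hydroxy of compound 3, so the step of a 5.0-fold lower number from compound 1 to compound 3 (0.69 log units; beyond the scatter) bears on it only as background. Within the data shown here, the closest precedent is a 5.4-fold lower number from compound 1 to compound 2 (0.73 log units; beyond the scatter) and it also replaced phenyl with a substituted phenyl, though with different groups. Among the measured compounds shown here, no measured compound carries both a hydroxy and a substituted phenyl, so whether the two steps add up is untested. The step expected here is a 3.3-fold lower number from compound 3 to compound 4 (0.52 log units; beyond the scatter) and it is expected to run in the same direction as that precedent, but somewhat smaller. Compound 4 is estimated at 2500 nM (expected range 600 nM to 9000 nM).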

Compound 4, concentration for 50% growth inhibition: 7100 nM
Compound 4: the middle estimate sits 2.8-fold (0.45 log units) below what was measured; the measured number falls inside the stated range.
By their numbers in this assay, from the lowest: compounds 4, 2 and 3 (each within the scatter of the next); then compound 1.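

In this assay, dimethylamino on an aromatic carbon para to a large group gives a 1.2-fold lower number from compound 3 to compound 4 (0.07 log units; within the scatter), so with the hydroxy in place, turning phenyl into 4-(dimethylamino)phenyl leaves the growth-inhibition number unresolved from that of compound 3. The earlier substitution of this phenyl, a 5.4-fold lower number from compound 1 to compound 2 (0.73 log units; beyond the scatter), lay beyond the scatter, but it involved a different group on a core without the hydroxy, so the two steps cannot separate the effect of the group from that of the hydroxy. Nothing available accounts for the small size of the new step.

Going by these compounds, what dimethylamino does on the core of compound 1, without the hydroxy, remains open. Also open, on these data alone, is whether a carboxylic acid or a primary amine at this same place would give a step beyond the scatter.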